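A few compounds are considered here, and "the series" means these few. Any claim that something is new, unique, unknown or untested is made for them only; others in the source may bear on it.

Measured compounds in a functional assay on HCT-116 cells (Homo sapiens) for cytotoxicity, read by MTT assay, with a stated time of 72 h; a higher number here means a weaker inhibitor, a lower number a stronger inhibitor:
- compound 1 `COc1ncc(-c2ccc3nccc(-c4ccc(C)cc4)c3c2)cc1NS(=O)(=O)c1ccc(F)cc1F`: 2540 nM
- compound 2 `CCN(Cc1ccc(-c2ccnc3ccc(-c4cnc(OC)c(NS(=O)(=O)c5ccc(F)cc5F)c4)cc23)cc1)C1CCCCC1`: 223 nM
- compound 3 `COc1ncc(-c2ccc3nccc(-c4ccc(CN5CCCC5)cc4)c3c2)cc1NS(=O)(=O)c1ccc(F)cc1F`: 18.8 nM

Compound 3 stands lowest of the three; the nearest measured neighbour is separated by a 12-fold lower number from compound 2 to compound 3 (1.07 log units; beyond the scatter), the furthest by a 140-fold lower number from compound 1 to compound 3 (2.13 log units; beyond the scatter).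

Compound 4 `COc1ncc(-c2ccc3nccc(-c4ccc(CN5CCN(C)CC5)cc4)c3c2)cc1NS(=O)(=O)c1ccc(F)cc1F` is not yet measured. It differs from compound 3 by 4-methylpiperazin-1-yl in place of pyrrolidin-1-yl on a saturated chain carbon bound to an aromatic carbon.

Among the measured compounds shown here, three measured steps touch the same saturated chain carbon: an 11-fold lower number from compound 1 to compound 2 (1.06 log units; beyond the scatter), a 140-fold lower number from compound 1 to compound 3 (2.13 log units; beyond the scatter) and a 12-fold lower number from compound 2 to compound 3 (1.07 log units; beyond the scatter). Both amine-bearing compounds sit far below compound 1, and the identity of the amine still shifted the number markedly between compound 2 and compound 3. A step no larger than that is expected for compound 4, most likely a modest move upward: a 2.1-fold higher number from compound 3 to compound 4 (0.33 log units; beyond the scatter). Compound 4 is estimated at 40 nM, within 10 nM to 160 nM.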

Compound 4, half-maximal inhibitory concentration: 43.9 nM
Compound 4: middle estimate off by 1.1-fold (0.04 log units), on the low side; low and high end bracket the measured number.
By their numbers in this assay, from the lowest: compound 3; then compound 4; then compound 2; then compound 1.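

In this assay, 4-methylpiperazin-1-yl on this saturated chain carbon retains a large gain over hydrogen (a 58-fold lower number from compound 1 to compound 4 (1.76 log units; beyond the scatter)) and also improves on cyclohexyl(ethyl)amino (a 5.1-fold lower number from compound 2 to compound 4 (0.71 log units; beyond the scatter)), so both ring amines now lie below the open amine. Pyrrolidin-1-yl nevertheless remains ahead, and the swap to the six-membered ring with its second nitrogen costs only a modest step (a 2.3-fold higher number from compound 3 to compound 4 (0.37 log units; beyond the scatter)). No evidence is available to explain this order of amines.

From the compounds shown here alone, whether ring size or the second ring nitrogen sets this gap remains open. Piperidin-1-yl and morpholin-4-yl on the same carbon would separate the two.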